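A few compounds are considered here, and "the series" means these few. Any claim that something is new, unique, unknown or untested is made for them only; others in the source may bear on it.

In an ADME assay on CCRF-CEM cells (Homo sapiens) for cytotoxicity, with a stated time of 3 days (a higher number here means that more compound is tolerated, a lower number that less compound is tolerated), compound 1 `O=c1ccn(C2C=CC(O)C2)c(=O)n1Cc1ccccc1` gives > 250000 nM, which is a limit of the assay. Compound 2 `Cc1ccc(Cn2c(=O)cc(C)n(C3C=CC(OC(=O)c4ccccc4)C3)c2=O)cc1` gives a measured number of 20000 nM. Compound 3 `Cc1ccc(Cn2c(=O)ccn(C3C=CC(OC(=O)c4ccccc4)C3)c2=O)cc1` gives > 25000 nM, which is also a limit and not a number, so its position is only bounded on one side.

Compound 4 `Cc1ccc(Cn2c(=O)ccn(C3C=CC(OC(=O)c4ccccc4)C3)c2=O)c(C)c1` changes the 4-methylbenzyl of compound 3 to 2,4-dimethylbenzyl, with methyl in place of hydrogen on an aromatic carbon, ortho to a large group and meta to a methyl group: methyl in place of hydrogen on an aromatic carbon.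

Going by the values given here, one measured step bears on this change: an at least 1.2-fold higher number from compound 2 to compound 3 (0.09 log units; that floor lies within the scatter). It also exchanges methyl and hydrogen on an aromatic carbon, but at a different place in the molecule and in the opposite sense. Its floor lies within the scatter, so it gives only weak guidance and favours no direction. A change beyond the scatter in this assay is therefore not expected, and compound 4 may well reach a limit again.

The expected size is a number no higher from compound 3 to compound 4 (the limit leaves the size open), which is an estimate resting on this single step. For compound 4 the estimated value is 25000 nM, with an expected range from 10000 nM to 60000 nM.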

Compound 4, half-maximal cytotoxic concentration: 31000 nM
For compound 4 the middle estimate is 1.2-fold (0.09 log units) below the measured one; the measured number falls inside the stated range.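

No step can be read from compound 3 to compound 4, since the value of compound 3 in this assay is a limit and not a number: the limit of > 25000 nM in this assay, at which 1 of the 4 values shown sits.

The compounds shown leave open whether methyl in place of hydrogen, turning 4-methylbenzyl into 2,4-dimethylbenzyl, moves the number in this assay at all, and in which direction.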